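From Fluoro to Trifluoromethyl: Expecting Compound 4

The compounds below may be only part of what the source reports. "The series", "measured", "known", "first", "only" and "open" are said of these compounds alone.

Compound 1 `O=C(O)c1csc(-n2nc(-c3ccccc3)c3c2CCCCC3)n1`: 1000 nM
Compound 2 `Nc1ccc2c(-c3ccccc3)nn(-c3nc(C(=O)O)cs3)c2c1`: 19 nM
Compound 3 `O=C(O)c1csc(-n2nc(-c3ccc(F)cc3)c3ccccc32)n1`: 4.5 nM

These three compounds were measured in an assay on isolated protein for antagonist activity at prostaglandin E2 receptor EP1 subtype (Homo sapiens), read by reporter gene assay; on this read-out higher numbers stand for weaker inhibition and lower numbers for stronger inhibition. Compound 3 gives the lowest number of the three, with 4.5 nM. Compound 2 stands higher, beyond the usual scatter, and compound 1 stands far higher still. Compound 4 `O=C(O)c1csc(-n2nc(-c3ccc(C(F)(F)F)cc3)c3ccccc32)n1` has not yet been measured. It differs from compound 3 in one place: trifluoromethyl in place of fluoro on an aromatic carbon. Within the data shown here, no measured pair shows this particular change, so its effect is unknown from these data. The expected step from compound 3 to compound 4 is a 1.3-fold higher number from compound 3 to compound 4 (0.12 log units; within the scatter), a change not expected to go beyond the scatter in either direction. Compound 4 is therefore estimated at 6 nM, with a range from 2 nM to 20 nM.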

Compound 4, half-maximal inhibitory concentration: 140 nM
Estimate against measurement, compound 4: 23-fold (1.37 log units) below, outside the stated range (above it).
By their numbers in this assay, from the lowest: compound 3; then compound 2; then compound 4; then compound 1.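

The position para to a large group proves sensitive to what sits on it: in this assay, trifluoromethyl in place of fluoro gives a 31-fold higher number from compound 3 to compound 4 (1.49 log units; beyond the scatter), a large loss of inhibition from one small change. Fluoro and trifluoromethyl therefore cannot be treated as interchangeable at this position on this core. Nothing available explains why the step is so large.

As far as these compounds go, whether a methyl, a chlorine atom or an amine here would give a number closer to that of compound 3 or compound 4 stays open. From the compounds shown here alone, it is also open whether the same change would cost as much on the core of compound 2.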